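Phenyl to 4-nitrophenyl: expectation for compound 4

The compounds below may be only part of what the source reports. "The series", "measured", "known", "first", "only" and "open" are said of these compounds alone.

In a functional assay on PC-3 cells (Homo sapiens) for cytotoxicity, read by MTT assay, with a stated time of 48 h (on this read-out higher numbers stand for weaker inhibition and lower numbers for stronger inhibition), compound 3 `COc1cc(-n2c(-c3ccccc3)cn(C(C)=O)c2=O)cc(OC)c1OC` gives only a limit, > 50000 nM. This places compound 3 at the limit of > 50000 nM in this assay, at which 1 of the 3 values shown sits, so any step from it starts from a limit and not from a number.

Compound 4 `COc1cc(-n2c(-c3ccc([N+](=O)[O-])cc3)cn(C(C)=O)c2=O)cc(OC)c1OC` differs from compound 3 in one place: nitro in place of hydrogen on an aromatic carbon. This is nitro in place of hydrogen on an aromatic carbon, para to a large group, or phenyl to 4-nitrophenyl.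

No nitro change has been measured in this series. The nearest evidence comes from a different pair with a larger substitution pattern. In this assay, compound 1 `COc1ccc(-c2cn(C(=O)Nc3cc(OC)c(OC)c(OC)c3)c(=O)n2-c2cc(OC)c(OC)c(OC)c2)cc1` gives 49700 nM. In the same assay, compound 2 `COc1ccc(-c2cn(C(=O)Nc3cc(OC)c(OC)c(OC)c3)c(=O)n2-c2cc(OC)c(OC)c(OC)c2)cc1N` gives 10000 nM. That pair shows a 5.0-fold lower number from compound 1 to compound 2 (0.70 log units; beyond the scatter), with amino in place of hydrogen on an aromatic carbon. Among the compounds with values here, it is the only measured step, and it involves a different group, so it bears on the present change only loosely. It suggests that one substituent on an aromatic carbon can move this read-out modestly toward lower numbers, and nothing measured points to a larger move.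

The expected step is an at least 1.4-fold lower number from compound 3 to compound 4 (0.15 log units; that floor lies within the scatter), and a second reading that gives only a limit would fit this expectation equally well. Compound 4 is estimated at 35000 nM, with an expected range of 10000 nM to 90000 nM.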

Compound 4, half-maximal inhibitory concentration: 32900 nM
The estimate for compound 4 lay 1.1-fold (0.03 log units) above the measured number; the measured number falls inside the stated range.
By their numbers in this assay, from the lowest: compound 2; then compounds 4 and 1 (each within the scatter of the next). At a limit, above all of these: compound 3.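

In this assay, phenyl to 4-nitrophenyl gives an at least 1.5-fold lower number from compound 3 to compound 4 (0.18 log units; that floor lies within the scatter), so the true size of this change remains unfixed and only its direction is suggested. With this change, compound 4 gives 32900 nM, a measured number on this smaller frame, which provides a firm reference point for further changes at this position on the aromatic ring. Compound 3 remains a limit and not a number, and it is the only compound shown with such a reading: the limit of > 50000 nM in this assay, at which 1 of the 4 values shown sits.

The compounds shown leave open whether the gain depends on nitro itself or whether another group at the same place, such as a carboxylic acid, trifluoromethyl or a chlorine atom, would give a similar or a clearly different number. They also leave open how nitro would behave on the larger frame of compound 1, and whether moving it to another carbon of the same ring would change the read-out.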